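Dichlorophenyl for Hydroxyphenyl on a Sulfonamide: Cytotoxicity Outlook

This account rests on a few compounds, and the source may have more. Where it says the series, first, only, none or still open, it means among the compounds named here.

In an ADME assay on HEK293 cells (Homo sapiens) for cytotoxicity, read by resazurin assay, with a stated time of 48 h (a higher number here means that more compound is tolerated, a lower number that less compound is tolerated), compound 1 `O=S(=O)(Nc1ccc(-c2nc3ccccc3o2)cc1)c1cccc(O)c1` reaches only the limit of the assay, > 100000 nM. Compound 2 `O=S(=O)(Nc1ccc2oc(-c3ccccc3)nc2c1)c1cccs1` gives 97000 nM in this assay. Compound 3 `O=S(=O)(Nc1ccc2oc(-c3ccccc3)nc2c1)c1ccc(O)cc1` likewise sits at the limit, > 100000 nM. For the measured compounds named here, the one measured step, an at least 1.0-fold higher number from compound 2 to compound 3 (0.01 log units; that floor lies within the scatter), changes the group on the sulfonyl sulfur and stays within the scatter. Compound 1 therefore stands where most of these compounds stand, at the limit of > 100000 nM in this assay, at which 2 of the 3 values shown sit. Compound 4 `O=S(=O)(Nc1ccc(-c2nc3ccccc3o2)cc1)c1ccc(Cl)c(Cl)c1` differs from compound 1 by 3,4-dichlorophenyl in place of 3-hydroxyphenyl on a sulfonyl sulfur. Going by the values given here, because the only comparable step, an at least 1.0-fold higher number from compound 2 to compound 3 (0.01 log units; that floor lies within the scatter), showed no change beyond the scatter, no clear movement is expected here either. Compound 4 is expected to give about 70000 nM, within 20000 nM to 200000 nM. The expected step is an at least 1.4-fold lower number from compound 1 to compound 4 (0.15 log units; that floor lies within the scatter).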

Compound 4, half-maximal cytotoxic concentration: > 100000 nM
Compound 4 was reported as a limit; the forecaster's own chance of this, stated with the estimate: 40%; at least 1.4-fold (0.15 log units) between middle value and limit.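

In this assay, for the compounds shown here, compound 1 and compound 4 both stand at a limit, so no step between them can be read. The compounds shown leave open whether 3,4-dichlorophenyl in place of 3-hydroxyphenyl changes how much compound is tolerated.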